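The source may report more compounds than this note shows. Statements on the series, on what has been measured and on what is new or still open speak of the compounds shown alone.

Within the data shown here, only two compounds have been measured so far in a physicochemical assay for solubility, using the shake flask method, in simulated intestinal fluid, measured as kinetic solubility, with a stated time of 2 h, at 25 degrees C, at pH 6.5; a lower number here means a less soluble compound, a higher number a more soluble compound. There, compound 1 `Cc1nc(C(=O)OC2CC2)c(N)c2c1C(=O)N(Cc1ccccc1)C2=O` gives 202000 nM and compound 2 `Cc1noc(-c2nc(C)c3c(c2N)C(=O)N(CC2CCNCC2)C3=O)n1` gives 160000 nM. These two numbers lie within the usual scatter of repeated measurements, so compound 2 stands level with compound 1 and neither can be ranked above the other. They also differ in more than one place, so they do not show what any single change does.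

The next compound, compound 3 `Cc1noc(-c2nc(C)c3c(c2N)C(=O)N(Cc2cccc(F)c2)C3=O)n1`, keeps everything in compound 2 except one group: 3-fluorophenyl stands in place of piperidin-4-yl on a saturated chain carbon bound to an amide-type nitrogen in a ring (3-fluorophenyl in place of piperidin-4-yl on a saturated chain carbon bound to an amide-type nitrogen in a ring). Cut one bond further out, this reads as (piperidin-4-yl)methyl becoming 3-fluorobenzyl.

Among the measured compounds shown here, no measured pair isolates this swap, so the forecast is a judgement and stays wide. It starts from compound 2 at 160000 nM. A moderate fall beyond the scatter is expected, with the estimated step of a 2.7-fold lower number from compound 2 to compound 3 (0.43 log units; beyond the scatter). Compound 3 is expected to give about 60000 nM, with an estimated range from 15000 nM to 170000 nM.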

Compound 3, solubility: < 5000 nM
Compound 3: only a limit was reported; the forecaster's own chance of this, stated with the estimate: 10%; middle value at least 12-fold (1.07 log units) from the limit.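

Among these compounds, compound 1 and compound 2 could say nothing about any single change, but here only one group differs: in this assay, replacing it gives an at least 32-fold lower number from compound 2 to compound 3 (1.50 log units; beyond the scatter) on the scale of that read-out. The group on the saturated chain carbon bound to an amide-type nitrogen in a ring therefore has a large bearing on this reading: piperidin-4-yl, a non-aromatic ring with a hydrogen-bond donor and acceptor, gives way to 3-fluorophenyl, an aromatic ring of carbon with neither. From the compounds shown here alone, the reading for compound 3 is a limit and not a number, so the step gives only the smallest possible size of the fall, and its full size stays unknown: the limit of < 5000 nM in this assay, at which 1 of the 3 values shown sits.

The compounds shown leave open which part of the swap carries the fall, whether the loss of the ring nitrogen, the arrival of the aromatic ring or the fluorine. A morpholine ring, a pyridine ring or an open-chain amine at this place, with the rest of compound 2 unchanged, would help to pull these parts apart.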